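The source may report more compounds than this note shows. Statements on the series, on what has been measured and on what is new or still open speak of the compounds shown alone.

Going by the values given here, compound 2, `O=c1[nH]c2ccccc2n1CCCCN1CCN(C(c2ccccc2)c2ccccc2)CC1`, is the only member of this set with a numerical result in an assay on RPMI-8226 cells for antagonist activity at P2X purinoceptor 7 (Homo sapiens), read by calcium flux (a higher number here means a weaker inhibitor, a lower number a stronger inhibitor), where compound 2 gives 180 nM. Compound 1, `O=c1[nH]c2ccccc2n1CCCN1CCN(S(=O)(=O)c2ccc(F)cc2)CC1`, is known in this assay only by a limit, > 10000 nM. Among the compounds with values here, that limit is the one noted in the limit of > 10000 nM in this assay, at which 1 of the 2 values shown sits, so compound 2 stands alone as the single compound whose potency has actually been put on a number, with nothing in the data to rank it against.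

Compound 3, `Cc1cc2ncn(CCCCN3CCN(C(c4ccccc4)c4ccccc4)CC3)c2cc1C`, has not yet been measured in this assay. It differs from compound 2 by a group of 11 heavy atoms (9 carbon, 2 nitrogen; one five-membered aromatic ring with 2 hetero atoms, one six-membered aromatic ring of carbon only) in place of a group of 10 heavy atoms (7 carbon, 2 nitrogen, 1 oxygen; one five-membered aromatic ring with 2 hetero atoms, one six-membered aromatic ring of carbon only), on a saturated chain carbon, four bonds along the chain from an amine nitrogen in a ring. Within the data shown here, no measured pair in the set isolates this kind of exchange, so the data give no direct guide to the size or direction of the step.

Taking compound 2 at 180 nM as the only anchor, the step from compound 2 to compound 3 is expected to be a modest loss of potency, a 2.8-fold higher number from compound 2 to compound 3 (0.44 log units; beyond the scatter), with a real chance that it stays within the usual scatter. On that basis compound 3 is estimated at 500 nM, with a range from 120 nM to 3000 nM.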

Compound 3, half-maximal inhibitory concentration: 770 nM
Compound 3: middle estimate off by 1.5-fold (0.19 log units), on the low side; the measured number falls inside the stated range.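

Going by these compounds alone, compound 3 gives the first step that can be read in this assay: putting 5,6-dimethyl-1H-benzimidazol-1-yl on the saturated chain carbon, four bonds along the chain from an amine nitrogen in a ring, gives a 4.3-fold higher number from compound 2 to compound 3 (0.63 log units; beyond the scatter). This is a modest step, and it shows that a measurable inhibitor remains after the exchange, even though the group that enters has 0 hydrogen-bond donors and no oxygen, whereas the group that leaves has 1 hydrogen-bond donor and 1 oxygen. The exchange changes several features at once, however, and nothing measured in this set accounts for the size or direction of the step.

The compounds shown leave open whether the step follows from the missing hydrogen-bond donor and oxygen or from the two added methyl groups, a question that an unsubstituted 1H-benzimidazol-1-yl group at the same place could help to separate. They also leave open whether the same exchange would give a step of similar size on a shorter chain, or with a group other than the two phenyl rings of the shared core.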